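Cyano for Methylsulfonyl on the Amide Side Chain

This account rests on a few compounds, and the source may have more. Where it says the series, first, only, none or still open, it means among the compounds named here.

Of the compounds shown here, three sharing one core have been measured in an ADME assay on microsomes from liver (Mus musculus) for metabolic stability; a higher number here means that the compound lasts longer, a lower number that the compound disappears faster. Compound 1 `C[C@H](CSc1nonc1/C(=N/O)Nc1ccc(F)c(Br)c1)NC(=O)CS(N)(=O)=O` gives 0.537 h. Compound 2 `NS(=O)(=O)CC(=O)NCCSc1nonc1/C(=N/O)Nc1ccc(F)c(Br)c1` gives 1.12 h, and the change a 2.1-fold higher number from compound 1 to compound 2 (0.32 log units; beyond the scatter). Compound 3 `CS(=O)(=O)CC(=O)NCCSc1nonc1/C(=N/O)Nc1ccc(F)c(C(F)F)c1` gives 0.765 h, the second highest of the three numbers; its gap to compound 1 and its gap to compound 2 both lie within the scatter, so no order among these three can be claimed. Compound 2 and compound 3 differ in more than one place, so their two values can only be set side by side.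

The next compound, compound 4 `N#CCC(=O)NCCSc1nonc1/C(=N/O)Nc1ccc(F)c(C(F)F)c1`, differs from compound 3 in one place: cyano in place of methylsulfonyl on a saturated chain carbon bound to a carbonyl carbon. Among the compounds with values here, no measured step bears on this exchange: the single step from compound 1 to compound 2 concerns a methyl on a saturated chain carbon bound to an amide-type nitrogen, not the group on the saturated chain carbon bound to the carbonyl carbon. Within the data shown here, with no precedent in these data, the step expected in this assay is a 1.0-fold lower number from compound 3 to compound 4 (0.01 log units; within the scatter), one within the scatter. Compound 4 is therefore estimated to give 0.75 h in this assay, with a range from 0.35 h to 1.6 h.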

Compound 4, half-life: 0.278 h
Compound 4: middle estimate off by 2.7-fold (0.43 log units), on the high side, outside the stated range (below it).
By their numbers in this assay, from the lowest: compounds 4, 1, 3 and 2 (each within the scatter of the next, the first and the last beyond it).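

In this assay the group on a saturated chain carbon bound to a carbonyl carbon proves able to shift the half-life: the exchange of methylsulfonyl for cyano brings a 2.8-fold lower number from compound 3 to compound 4 (0.44 log units; beyond the scatter) with the rest of the molecule unchanged. Within the data shown here, until now the only step read beyond the scatter concerned a methyl on the saturated chain carbon bound to an amide-type nitrogen, so this is the first sign that a second place on the amide side chain also matters for this read-out. The entering cyano has fewer heavy atoms and one hydrogen-bond acceptor fewer than the methylsulfonyl it replaces, but the data offer no explanation for the step, and nothing shown ties it to those counts.

The compounds shown leave open whether the lower number follows from the arrival of cyano or the departure of methylsulfonyl, which a carboxylic acid, an amine or a longer chain at this place could help to separate. They also leave open whether the same exchange would give a step of similar size on the bromine-bearing side of the series, to which compound 1 and compound 2 belong.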